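A third methoxy group on the benzylamine arm

The compounds below may be only part of what the source reports. "The series", "measured", "known", "first", "only" and "open" are said of these compounds alone.

Compound 1, `Nc1cc(N)c2nc(-c3ccccc3)c(Oc3ccc(Cl)c(Cl)c3)nc2c1`, in a functional assay on MDA-MB-435 cells (Homo sapiens) for inhibition, read by sulforhodamine B assay, with a stated time of 48 h (a higher number here means that more compound is tolerated, a lower number that less compound is tolerated), gives 93300 nM.
Compound 2, `Nc1cc(N)c2nc(-c3ccccc3)c(NCc3ccc(Cl)c(Cl)c3)nc2c1`, in this assay gives 52500 nM.
Compound 3, `COc1ccc(CNc2nc3cc(N)cc(N)c3nc2-c2ccccc2)cc1OC`, in this assay gives 8510 nM.

Among these three numbers compound 3 stands lowest; compound 2 lies nearest above it and compound 1 furthest above it, both gaps beyond the scatter. Compound 4, `COc1cc(CNc2nc3cc(N)cc(N)c3nc2-c2ccccc2)cc(OC)c1OC`, differs from compound 3 by methoxy in place of hydrogen on an aromatic carbon, so the ring on the saturated chain carbon carries three methoxy groups instead of two. Among the compounds with values here, only one measured step touches this part of the molecule, the swap of the whole aryl group on that chain carbon, a 6.2-fold lower number from compound 2 to compound 3 (0.79 log units; beyond the scatter). Within the data shown here, no measured step adds a single methoxy group to a ring that already bears two, so the size of the present change has no direct precedent. Because the step of a 6.2-fold lower number from compound 2 to compound 3 (0.79 log units; beyond the scatter) favoured the methoxylated ring, a further methoxy group is expected to leave the number near that of compound 3 or move it modestly lower, not beyond the scatter with confidence. Compound 4 is therefore expected to give 7000 nM, within 2500 nM to 20000 nM. The expected step is a 1.2-fold lower number from compound 3 to compound 4 (0.08 log units; within the scatter).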

Compound 4, concentration lethal to 50% of the cells: 2880 nM
Compound 4: the middle estimate sits 2.4-fold (0.39 log units) above what was measured, within the range that was stated.
By their numbers in this assay, from the lowest: compound 4; then compound 3; then compounds 2 and 1 (each within the scatter of the next).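

In this assay, within the data shown here, the earlier compounds showed only the exchange of a whole substituted ring, whereas here one added methoxy group, ortho to a methoxy group and meta to a large group, gives a 3.0-fold lower number from compound 3 to compound 4 (0.47 log units; beyond the scatter) and thus moves the number beyond the scatter on its own. A ring that already carries two methoxy groups therefore still responds to a third, and the lower number shows that this aromatic carbon need not stay bare, with compound 4 now lowest of the four. Nothing among the data shown accounts for this step.

As far as these compounds go, whether a hydroxy group, a fluorine atom or an ethoxy group on the same carbon would move the number in the same way remains open. So does whether the step depends on the two methoxy groups already present on the ring.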